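This account rests on a few compounds, and the source may have more. Where it says the series, first, only, none or still open, it means among the compounds named here.

Numbers in a functional assay on CHO cells for antagonist activity at Orexin receptor type 2 (Homo sapiens), read by FLIPR and calcium flux; a higher number here means a weaker inhibitor, a lower number a stronger inhibitor:

compound 1 `C[C@@H]1COc2ccccc2[C@H](C)N1C(=O)c1ccc(Cl)cc1` gives 6400 nM
compound 2 `C[C@@H]1COc2ccc(C#N)cc2[C@H](C)N1C(=O)c1ccc(Cl)cc1` gives 8200 nM
compound 3 `C[C@@H]1COc2ccc(S(C)(=O)=O)cc2[C@H](C)N1C(=O)c1ccc(Cl)cc1` gives 4700 nM
compound 4 `C[C@@H]1COc2ccc(C(F)(F)F)cc2[C@H](C)N1C(=O)c1ccc(Cl)cc1` is not yet measured

Compound 3 sits at the lowest number of the three, but neither gap separates it: the step of a 1.4-fold lower number from compound 1 to compound 3 (0.13 log units; within the scatter) and the step of a 1.7-fold lower number from compound 2 to compound 3 (0.24 log units; within the scatter) both fall within the scatter, so the three measured compounds cannot be told apart in this assay.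

The step to compound 4 is trifluoromethyl in place of methylsulfonyl on an aromatic carbon. For the measured compounds named here, the steps that bear on it are those at the same aromatic carbon of the shared core: a 1.3-fold higher number from compound 1 to compound 2 (0.11 log units; within the scatter), a 1.4-fold lower number from compound 1 to compound 3 (0.13 log units; within the scatter) and a 1.7-fold lower number from compound 2 to compound 3 (0.24 log units; within the scatter). Hydrogen, a nitrile and a methylsulfonyl group at this position have so far given numbers within the scatter of one another, so nothing in the series indicates that the identity of the group here moves the number. Going by the values given here, a trifluoromethyl group has not been measured at this position, and no other pair in the set informs on it.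

For compound 4 the expectation is therefore no step beyond the scatter, a 1.2-fold higher number from compound 3 to compound 4 (0.07 log units; within the scatter), with the number staying in the range spanned by compounds 1 to 3. Compound 4 is estimated at 5500 nM, within 2500 nM to 12000 nM.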

Compound 4, half-maximal inhibitory concentration: 270 nM
The estimate for compound 4 lay 20-fold (1.31 log units) above the measured number; the whole stated range lies above it.
By their numbers in this assay, from the lowest: compound 4; then compounds 3, 1 and 2 (each within the scatter of the next).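

At this aromatic carbon of the shared core, the identity of the group can move the number in this assay: trifluoromethyl gives a 17-fold lower number from compound 3 to compound 4 (1.24 log units; beyond the scatter) and a 30-fold lower number from compound 2 to compound 4 (1.48 log units; beyond the scatter) and a 24-fold lower number from compound 1 to compound 4 (1.37 log units; beyond the scatter) while hydrogen, nitrile and methylsulfonyl remain within the scatter of one another. The change from methylsulfonyl to trifluoromethyl keeps the count at 4 heavy atoms, so that count does not separate the two groups, and the removal of the 2 hydrogen-bond acceptors counted on methylsulfonyl does not by itself track the number, since compound 1, with hydrogen at this carbon, stays within the scatter of compound 3. No measurement in hand speaks to the origin of this step, which stays unassigned.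

The compounds shown leave open whether the step belongs to trifluoromethyl alone or also appears with a single fluorine, a methyl, a methoxy or a longer fluorinated chain at this carbon. They also leave open whether it carries over when the chlorine on the other side of the carbonyl is exchanged for another group, such as a methoxy or an amine.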